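Urea aryl exchange on the shared core: compound 4

The compounds below may be only part of what the source reports. "The series", "measured", "known", "first", "only" and "open" are said of these compounds alone.

Measured so far in a functional assay on T-24 cells (Homo sapiens) for antiproliferative activity, read by MTT assay, with a stated time of 48 h; on this read-out lower numbers stand for stronger inhibition and higher numbers for weaker inhibition:
compound 1 `O=C(Nc1cccc(CNc2nccnc2Cl)c1)Nc1ccccc1F`, 7450 nM
compound 2 `O=C(Nc1cccc(CNc2nccnc2Cl)c1)NC1CCCCC1`, > 40000 nM
compound 3 `O=C(Nc1cccc(CNc2nccnc2Cl)c1)Nc1ccc(Cl)cc1Br`, 6650 nM

Compound 2 gives a limit of the assay rather than a number (the limit of > 40000 nM in this assay, at which 1 of the 3 values shown sits). Of the two numbers, compound 1 stands with compound 3 within the scatter, as a 1.1-fold lower number from compound 1 to compound 3 (0.05 log units; within the scatter) shows, so the two cannot be ordered. The two steps that reach beyond the scatter both involve compound 2: an at least 5.3-fold higher number from compound 1 to compound 2 (0.72 log units; beyond the scatter) and an at least 6.0-fold lower number from compound 2 to compound 3 (0.77 log units; beyond the scatter). Exchanging an aryl group on the urea nitrogen for cyclohexyl therefore costs markedly, while exchanging one aryl group for another has so far cost nothing measurable.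

Compound 4 `O=C(Nc1cccc(CNc2nccnc2Cl)c1)Nc1ccc(F)c(Cl)c1` differs from compound 1 as follows: 3-chloro-4-fluorophenyl in place of 2-fluorophenyl on an amide-type nitrogen. For the measured compounds named here, this change keeps an aryl group on the amide-type nitrogen and alters only its halogen pattern, so the step that bears on it is the one from compound 1 to compound 3, which lay within the scatter; the two steps involving compound 2 concern a loss of the aryl group and are not of the same kind. In this assay no step beyond the scatter is expected for compound 4, with a 1.1-fold lower number from compound 1 to compound 4 (0.06 log units; within the scatter). Compound 4 is therefore estimated at 6500 nM, with a range from 2500 nM to 17000 nM.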

Compound 4, half-maximal inhibitory concentration: 4990 nM
Estimate against measurement, compound 4: 1.3-fold (0.11 log units) above; the range from low to high includes it.
By their numbers in this assay, from the lowest: compounds 4, 3 and 1 (each within the scatter of the next). At a limit, above all of these: compound 2.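

In this assay, 3-chloro-4-fluorophenyl on the amide-type nitrogen leaves the result within the scatter of both other aryl compounds, with a 1.5-fold lower number from compound 1 to compound 4 (0.17 log units; within the scatter) and a 1.3-fold lower number from compound 3 to compound 4 (0.12 log units; within the scatter), so the tolerance for exchanging one halogenated aryl group for another is not tied to the pattern of 2-fluorophenyl or 2-bromo-4-chlorophenyl. The separation from cyclohexyl now holds for all three aryl groups shown, with no compound here against it, and this third case reads an at least 8.0-fold lower number from compound 2 to compound 4 (0.90 log units; beyond the scatter). Compound 2 remains a limit and not a number, so the true size of that separation stays unknown: the limit of > 40000 nM in this assay, at which 1 of the 4 values shown sits.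

All aryl groups shown carry only halogens, so the effect of a methoxy group, an amine or a carboxylic acid on that ring remains open, as does that of an unsubstituted phenyl group. Cyclohexyl is the only non-aryl group shown, so it also remains open whether a benzyl group or a short chain such as ethyl on this nitrogen would track compound 2 or the aryl compounds.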